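The source may report more compounds than this note shows. Statements on the series, on what has been measured and on what is new or still open speak of the compounds shown alone.

Measured in a toxicity assay on Huh-7 cells (Homo sapiens) for cytotoxicity, with a stated time of 3 days; a lower number here means that less compound is tolerated, a higher number that more compound is tolerated:
Compound 1 `COc1ccc(-c2cn([C@@H]3O[C@H](CO)[C@@H](O)[C@@]3(C)O)c3ncnc(N)c23)cc1`: > 44000 nM
Compound 2 `C[C@@]1(O)[C@H](O)[C@@H](CO)O[C@H]1n1cc(-c2cccc3ccccc23)c2c(N)ncnc21`: > 44000 nM

Compound 2 gives > 44000 nM, which is a limit and not a number. Compound 1 gives > 44000 nM, which is also a limit. The pair therefore offers only (the limit of > 44000 nM in this assay, at which 2 of the 2 values shown sit).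

Compound 3 `C[C@@]1(O)[C@H](O)[C@@H](CO)O[C@H]1n1cc(-c2ccc3ccccc3c2)c2c(N)ncnc21` differs from compound 2 in one place: naphthalen-2-yl in place of naphthalen-1-yl on an aromatic carbon. The change is naphthalen-2-yl in place of naphthalen-1-yl on an aromatic carbon of a five-membered aromatic ring with 1 nitrogen, and the two compounds have the same atoms, joined differently.

Going by the values given here, the one measured step that bears on this is a step that the two limits leave unreadable from compound 1 to compound 2, which also changes the group at this place. It gives no size to carry over, so no step beyond the scatter is expected in this assay, and no direction can be assigned. The expected change is a number no higher from compound 2 to compound 3 (the limit leaves the size open). Compound 3 is estimated at 44000 nM, with an expected range of 15000 nM to 90000 nM.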

Compound 3, half-maximal cytotoxic concentration: 20100 nM
Compound 3: the middle estimate sits 2.2-fold (0.34 log units) above what was measured, within the range that was stated.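

In this assay, this place on the five-membered aromatic ring with 1 nitrogen proves sensitive not only to which group it carries but also to how that group is joined: naphthalen-2-yl in place of naphthalen-1-yl, with the same atoms joined differently, gives an at least 2.1-fold lower number from compound 2 to compound 3 (0.34 log units; beyond the scatter). Naphthalen-2-yl in place of 4-methoxyphenyl gives an at least 2.1-fold lower number from compound 1 to compound 3 (0.34 log units; beyond the scatter), which makes compound 3 the only compound here with a number rather than a limit, while the step from compound 1 to compound 2 cannot be read. Both readable steps start from a limit, so their true sizes stay open, and the earlier pair could show no difference at this place: the limit of > 44000 nM in this assay, at which 2 of the 3 values shown sit.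

The compounds shown leave open whether the lower number is particular to naphthalen-2-yl or would also appear with other groups at this place, such as an unsubstituted phenyl, an amine or a carboxylic acid. They also leave open whether the same change would have a similar effect on a core carrying a different group in place of the 3,4-dihydroxy-5-(hydroxymethyl)-3-methyloxolan-2-yl group.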